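The compounds below may be only part of what the source reports. "The series", "measured", "known", "first", "only" and "open" are said of these compounds alone.

Three compounds of this series have a number in an assay on isolated protein for inhibition of Caspase-8 (Homo sapiens); a lower number here means a stronger inhibitor, a higher number a weaker inhibitor. Compound 1 `O=C1C[C@H](NC(=O)[C@@H]2CN(C(=O)Nc3ccccc3)C[C@@H]3CCCC[C@H](NC(=O)c4ccccc4)C(=O)N32)C(O)O1` gives 601 nM, compound 2 `O=C1C[C@H](NC(=O)[C@@H]2COC[C@@H]3C/C=C\C[C@H](NC(=O)c4cccc(Cl)c4)C(=O)N32)C(O)O1` gives 1550 nM, and compound 3 `O=C1C[C@H](NC(=O)[C@@H]2COC[C@@H]3CCCC[C@H](NC(=O)c4cc5ccccc5s4)C(=O)N32)C(O)O1` gives 429 nM. Compound 2 stands highest of the three: compound 1 is nearest to it and compound 3 furthest, and both gaps lie beyond the scatter. Compound 4 `O=C1C[C@H](NC(=O)[C@@H]2COC[C@@H]3C/C=C\C[C@H](NC(=O)c4ccccc4)C(=O)N32)C(O)O1` is not yet measured in this assay. It differs from compound 2 in one place: hydrogen in place of chloro on an aromatic carbon. For the measured compounds named here, no pair of measured compounds shows this change, so no size can be read from the data. The expected step is a 1.2-fold higher number from compound 2 to compound 4 (0.06 log units; within the scatter), not beyond the scatter, tending if anything to a somewhat higher number. For compound 4 the estimate is 1800 nM, with a range of 700 nM to 4500 nM.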

Compound 4, half-maximal inhibitory concentration: 7900 nM
Compound 4: the middle estimate sits 4.4-fold (0.64 log units) below what was measured, and the stated range ends below it.
By their numbers in this assay, from the lowest: compounds 3 and 1 (each within the scatter of the next); then compound 2; then compound 4.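

In this assay, for the compounds shown here, the first one-place step is a 5.1-fold higher number from compound 2 to compound 4 (0.71 log units; beyond the scatter), on loss of the chloro from the six-membered aromatic ring. This position is therefore not indifferent to the change: on this core, the 3-chlorophenyl group gives a stronger inhibitor than phenyl, with the step beyond the scatter. Nothing available explains the size of this step. As far as these compounds go, whether fluoro, methyl, methoxy or an amine on the same aromatic carbon would match chloro remains open. Also open, from the compounds shown here alone, is whether adding chloro to the benzamido of compound 1 would give a similar step on the core of that compound.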